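Triazole anticonvulsants: phenethyl replacing 4-fluorophenyl

The source may report more compounds than this note shows. Statements on the series, on what has been measured and on what is new or still open speak of the compounds shown alone.

Measured so far in a functional assay on the whole organism (strain C57B/6) with Mus musculus as the target, in the maximal electroshock model; on this read-out lower numbers stand for an effect already at smaller amounts and higher numbers for an effect only at larger amounts of compound:
compound 1 `CCCCCCCc1nncn1-c1ccc(OCCCCCC)cc1`; this is a limit of the assay: > 40 mg/kg.
compound 2 `CCCCCCOc1ccc(-n2cnnc2-c2ccc(F)cc2)cc1`: 22 mg/kg.

Among the compounds with values here, compound 2 gives the only number in this assay; the other value is a limit. The next step is to compound 3 `CCCCCCOc1ccc(-n2cnnc2CCc2ccccc2)cc1`, differing by phenethyl in place of 4-fluorophenyl on an aromatic carbon. Within the data shown here, the one measured step at this position, an at least 1.8-fold lower number from compound 1 to compound 2 (0.25 log units; that floor lies within the scatter), moved from a chain to an aryl group and is itself only a floor within the scatter. Phenethyl returns part of the way toward a chain, so a small rise in the number is expected, and compound 3 is estimated at 30 mg/kg (range 15 mg/kg to 60 mg/kg), an expected step of a 1.4-fold higher number from compound 2 to compound 3 (0.13 log units; within the scatter).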

Compound 3, dose for half-maximal effect: 27.4 mg/kg
Compound 3: the middle estimate sits 1.1-fold (0.04 log units) above what was measured, and the stated range covers the measured number.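

In this assay, phenethyl and 4-fluorophenyl on this aromatic carbon are not told apart (a 1.2-fold higher number from compound 2 to compound 3 (0.10 log units; within the scatter)), so a saturated link ahead of the phenyl ring is tolerated on this read-out, which compound 2 alone could not show. Against the heptyl chain of compound 1, phenethyl gives only a floor within the scatter (an at least 1.4-fold lower number from compound 1 to compound 3 (0.16 log units; that floor lies within the scatter)), so no gain over the chain is established. The value of compound 1 is a limit of the assay: the limit of > 40 mg/kg in this assay, at which 1 of the 3 values shown sits.

As far as these compounds go, whether benzyl, phenylpropyl or an amine on the phenyl ring would move the number beyond the scatter remains open.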